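Dienone-triazole-coumarin series: methoxy removal on the aryl end

The compounds below may be only part of what the source reports. "The series", "measured", "known", "first", "only" and "open" are said of these compounds alone.

Three members of the series have been measured in a functional assay on HCT-116 cells (Homo sapiens) for inhibition, read by sulforhodamine B assay, with a stated time of 48 h, tested at 50 uM; a higher number here means more inhibition of growth at the concentration tested, a lower number less inhibition of growth. Compound 2 `COc1ccc(/C=C/C(=O)/C=C/c2ccc(OCc3cn(CCOc4cc(=O)oc5ccccc45)nn3)c(OC)c2)cc1OC` gives 82% and stands highest of the three numbers. Compound 1 `COc1ccccc1/C=C/C(=O)/C=C/c1ccc(OCc2cn(CCCCOc3cc(=O)oc4ccccc34)nn2)c(OC)c1` gives 43%, a number beyond the scatter below compound 2. Compound 3 `COc1cc(/C=C/C(=O)/C=C/c2cccs2)ccc1OCc1cn(CCCCCOc2cc(=O)oc3ccccc23)nn1` gives 31%, the lowest of the set and also beyond the scatter below compound 2. Among the measured compounds shown here, compounds 1 and 3 differ from compound 2 in more than one place at once, so no single-change step between measured compounds is available, and the gaps to compound 2 cannot be assigned to any one part of the structure.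

Compound 4 `COc1cccc(/C=C/C(=O)/C=C/c2ccc(OCc3cn(CCOc4cc(=O)oc5ccccc45)nn3)c(OC)c2)c1` is not yet measured. It differs from compound 2 in one place: hydrogen in place of methoxy on an aromatic carbon. For the measured compounds named here, the measured numbers offer no pair that isolates this change. The two compounds that lack the 3,4-dimethoxyphenyl group, compound 1 and compound 3, both sit well below compound 2, but each also carries a different chain on the triazole, so the step is uncertain in size. A moderate loss is expected, and the estimate means a step of a number 20 percentage points lower from compound 2 to compound 4 (beyond the scatter) in this assay. Compound 4 is expected to give 62%, within a range of 38% to 84%.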

Compound 4, percent growth inhibition at one concentration: 70%
Estimate against measurement, compound 4: 8 percentage points below; measured number inside the range.
By their numbers in this assay, from the lowest: compound 3; then compound 1; then compound 4; then compound 2.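

Among the compounds shown here, removing the methoxy from this aromatic carbon, ortho to a methoxy group and para to a large group, gives a number 12 percentage points lower from compound 2 to compound 4 (beyond the scatter) in this assay, the first reading that isolates a single change. With compound 4 at 70%, the change from 3,4-dimethoxyphenyl to 3-methoxyphenyl costs some growth inhibition at the concentration tested, but the second methoxy is not required for a substantial reading in this pair. Nothing at hand accounts for the size of this step.

For the compounds shown here, still open is whether the step keeps its size on a longer chain at the triazole than the one shared by compound 2 and compound 4, and what removing the remaining methoxy of compound 4 would give. Also open, on these data alone, is how a hydroxyl group, a fluorine atom or an amine at this aromatic carbon would compare with methoxy and with hydrogen.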